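The source may hold more compounds than are shown below. What is called first, only, known or untested is meant among the compounds shown, and "the series" means these compounds.

Compound 1 `CCCCOC(=O)c1cccc(-c2ccc(OCC)cc2)c1`: 100000 nM
Compound 2 `CCCCCCOC(=O)c1cccc(-c2ccc(OCC)cc2)c1`: > 200000 nM

In an assay on COS-7 cells for inhibition of patatin-like phospholipase domain-containing protein 2 (Mus musculus) (on this read-out lower numbers stand for stronger inhibition and higher numbers for weaker inhibition), compound 1 gives 100000 nM. For compound 2 the read-out is a limit of the assay, (the limit of > 200000 nM in this assay, at which 1 of the 2 values shown sits), and not a number. Compound 3 `CCOc1ccc(-c2cccc(C(=O)NC)c2)cc1` differs from compound 2 by methylamino in place of hexyloxy on a carbonyl carbon. Among the measured compounds shown here, the one measured step, an at least 2.0-fold higher number from compound 1 to compound 2 (0.30 log units; that floor lies within the scatter), concerns the chain on the ester oxygen and bears only loosely on an exchange of the whole hexyloxy group, so no direction is expected with any confidence. Compound 3 is therefore expected near 100000 nM, between 30000 nM and 200000 nM. The estimate implies an at least 2.0-fold lower number from compound 2 to compound 3 (0.30 log units; that floor lies within the scatter).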

Compound 3, half-maximal inhibitory concentration: > 200000 nM
Compound 3 was reported as a limit; the forecaster's own chance of this, stated with the estimate: 50%; middle value at least 2.0-fold (0.30 log units) from the limit.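

In this assay, exchanging the butoxy group on the carbonyl carbon for methylamino gives an at least 2.0-fold higher number from compound 1 to compound 3 (0.30 log units; that floor lies within the scatter), so this exchange shows no gain in inhibition over compound 1. The step from compound 2 to compound 3 cannot be read. Compound 3 is reported only as a limit, the same one as compound 2: the limit of > 200000 nM in this assay, at which 2 of the 3 values shown sit.

On these data alone, whether a carboxylic acid or a shorter methoxy group on this carbonyl carbon would give a number lower than that of compound 1 remains open. As far as these compounds go, how compound 2 and compound 3 truly rank also remains open.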